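Swapping Fluorine for Bromine on the Pendant Ring

This account rests on a few compounds, and the source may have more. Where it says the series, first, only, none or still open, it means among the compounds named here.

Two measured compounds share one core and differ only in the ring on the saturated chain carbon bound to a sulfur. Compound 1 `COc1cc(-c2nnc(SCc3c(F)cccc3F)o2)ccc1O` carries a 2,6-difluorophenyl there, and in an ADME assay on cells (Mus musculus, strain BALB/c) for cytotoxicity, read by MTT assay, with a stated time of 24 h (a higher number here means that more compound is tolerated, a lower number that less compound is tolerated), compound 1 gives 575000 nM. Compound 2 `COc1cc(-c2nnc(SCc3ccc(F)cc3)o2)ccc1O` carries a 4-fluorophenyl instead and gives 685000 nM. The step of a 1.2-fold higher number from compound 1 to compound 2 (0.08 log units; within the scatter). Of the two numbers, that of compound 2 is the higher, though its difference from compound 1 lies within the scatter, so the two cannot be told apart. Compound 3 `COc1cc(-c2nnc(SCc3ccc(Br)cc3)o2)ccc1O` is compound 2 with bromo in place of fluoro on an aromatic carbon. Among the compounds with values here, only the one measured step bears on this change, and it stayed within the scatter. The expected step of a 1.0-fold higher number from compound 2 to compound 3 (0.01 log units; within the scatter) is therefore a small one, with no direction beyond the scatter. Compound 3 is expected to give 700000 nM, between 350000 nM and 1400000 nM.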

Compound 3, half-maximal cytotoxic concentration: 455000 nM
The estimate for compound 3 lay 1.5-fold (0.19 log units) above the measured number, and the stated range covers the measured number.
By their numbers in this assay, from the lowest: compounds 3, 1 and 2 (each within the scatter of the next).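

In this assay, bromo in place of fluoro on an aromatic carbon gives a 1.5-fold lower number from compound 2 to compound 3 (0.18 log units; within the scatter) and stays within the scatter, so this first change of the halogen itself, with the rest of the ring kept, cannot be told from no change. The wider swap of 4-bromophenyl for 2,6-difluorophenyl gives a 1.3-fold lower number from compound 1 to compound 3 (0.10 log units; within the scatter) and also stays within the scatter, which means that compounds 1, 2 and 3 cannot be separated in this measure. No measurement of any other kind is available to help interpret these small steps.

On these data alone, all three compounds carry only halogens on the pendant ring, so it remains open how an amine or a carboxylic acid would read there. As far as these compounds go, a longer chain in place of the saturated chain carbon bound to a sulfur also remains open.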